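Swapping the Amine on Compound 3

The source may report more compounds than this note shows. Statements on the series, on what has been measured and on what is new or still open speak of the compounds shown alone.

For the measured compounds named here, in a functional assay on NCI-H460 cells (Homo sapiens) for cytotoxicity, read by MTT assay, with a stated time of 72 h (on this read-out higher numbers stand for weaker inhibition and lower numbers for stronger inhibition), compound 3 `CN(C)Cc1ccc2nc(NC(=O)N/N=C/c3cn(Cc4ccc(Cl)cc4)c4ccccc34)sc2c1` gives 290 nM as the lowest of the three numbers measured so far. Compound 4 `CC1CCN(Cc2ccc3nc(NC(=O)N/N=C/c4cn(Cc5ccc(Cl)cc5)c5ccccc45)sc3c2)CC1` is still unmeasured and carries 4-methylpiperidin-1-yl in place of dimethylamino on a saturated chain carbon bound to an aromatic carbon. Compound 1 `CC1CCN(Cc2ccc3nc(NC(=O)N/N=C/c4cn(Cc5ccc(Cl)cc5Cl)c5ccccc45)sc3c2)CC1` also carries 4-methylpiperidin-1-yl and gives 1660 nM while compound 2 `CC1CCN(Cc2ccc3nc(NC(=O)N/N=C/c4c[nH]c5ccccc45)sc3c2)CC1` gives 4130 nM in this assay as well. Going by the values given here, no measured step isolates this change. The only one, a 2.5-fold higher number from compound 1 to compound 2 (0.40 log units; beyond the scatter) when hydrogen replaces 2,4-dichlorobenzyl on an aromatic nitrogen, is modest and concerns another place. Among the compounds with values here, compound 1 at 1660 nM is the only guide, and it points to an expected rise in the number. The expected step in this assay is a 2.2-fold higher number from compound 3 to compound 4 (0.35 log units; beyond the scatter) in size. For compound 4 the estimated value is 650 nM with an expected range from 220 nM to 1900 nM in this measurement.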

Compound 4, half-maximal inhibitory concentration: 400 nM
For compound 4 the middle estimate is 1.6-fold (0.21 log units) above the measured one; measured number inside the range.
By their numbers in this assay, from the lowest: compounds 3 and 4 (each within the scatter of the next); then compound 1; then compound 2.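

In this assay the swap on the saturated chain carbon gives a 1.4-fold higher number from compound 3 to compound 4 (0.14 log units; within the scatter) and so leaves dimethylamino and the bulkier 4-methylpiperidin-1-yl indistinguishable here. With 4-methylpiperidin-1-yl in place, the group on the aromatic nitrogen counts for more: 4-chlorobenzyl in place of hydrogen gives a 10-fold lower number from compound 2 to compound 4 (1.01 log units; beyond the scatter) and hydrogen in place of chloro on an aromatic carbon gives a 4.2-fold lower number from compound 1 to compound 4 (0.62 log units; beyond the scatter) with the amine unchanged. No measurement here explains these steps. Still open, from the compounds shown here alone, is whether morpholin-4-yl or a primary amine at this place would match these two amines.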